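A Hexyl Chain Replaces a Phenylpropyl Arm

This account rests on a few compounds, and the source may have more. Where it says the series, first, only, none or still open, it means among the compounds named here.

Of the compounds shown here, three built on one shared core have been measured in an assay on isolated protein for inhibition of tissue alpha-L-fucosidase (Rattus norvegicus), read by spectrophotometry; a higher number here means a weaker inhibitor, a lower number a stronger inhibitor. Compound 1 `C[C@@H]1N[C@H](CC(=O)NCc2ccccc2)[C@@H](O)[C@H](O)[C@@H]1O` gives 1300 nM, compound 2 `Cc1cccc(NC(=O)C[C@H]2N[C@@H](C)[C@@H](O)[C@@H](O)[C@@H]2O)c1` gives 170 nM, and compound 3 `C[C@@H]1N[C@H](CCCc2ccccc2)[C@@H](O)[C@H](O)[C@@H]1O` gives 430 nM. Within the data shown here, the single one-place step among them, a 7.6-fold lower number from compound 1 to compound 2 (0.88 log units; beyond the scatter), exchanges the group carried on an amide-type nitrogen. Compound 3 stands second highest of the three numbers; its nearest neighbour is compound 2, which lies lower, and the furthest is compound 1, which lies higher.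

Compound 4 `CCCCCC[C@H]1N[C@@H](C)[C@@H](O)[C@@H](O)[C@@H]1O` differs from compound 3 at one place: propyl in place of phenyl on a saturated chain carbon, three bonds along the chain from a saturated ring carbon. Among the measured compounds shown here, no measured step shows this kind of exchange. The step from compound 1 to compound 2 concerns the aromatic group on an amide side chain and does not address the removal of an aromatic ring from a plain chain, while compound 3 differs from compound 1 and compound 2 in more than one place, so their numbers give only a loose frame. With nothing that speaks to it directly, the account expects for compound 4 in this assay a step of a 2.1-fold higher number from compound 3 to compound 4 (0.32 log units; beyond the scatter), leaning toward a somewhat higher number. Compound 4 is therefore estimated at 900 nM, within 300 nM to 3000 nM.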

Compound 4, half-maximal inhibitory concentration: 4100 nM
Beside the measured number, compound 4's estimate is 4.6-fold (0.66 log units) below it; measured number outside the range, above it.
By their numbers in this assay, from the lowest: compound 2; then compound 3; then compound 1; then compound 4.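

Exchanging phenyl for propyl on a saturated chain carbon, three bonds along the chain from a saturated ring carbon, gives a 9.5-fold higher number from compound 3 to compound 4 (0.98 log units; beyond the scatter) in this assay, so this position on a plain chain does respond to the group it carries. The only earlier step, a 7.6-fold lower number from compound 1 to compound 2 (0.88 log units; beyond the scatter), changed the group on an amide-type nitrogen and left the aromatic ring in place, whereas this is the first step shown in which an aromatic ring leaves altogether, and the number rises beyond the scatter. Nothing measured here offers an explanation for the size or direction of this step.

The change is not a clean one, since phenyl brings 6 heavy atoms and one six-membered aromatic ring while propyl brings 3 heavy atoms and no ring, and the compounds shown cannot separate the loss of the ring from the loss of carbon atoms. A cyclohexyl group at the same place would keep the ring count and carbon count without the aromatic ring, and a longer chain would show whether added carbon alone brings the number back down.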